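A few compounds are considered here, and "the series" means these few. Any claim that something is new, unique, unknown or untested is made for them only; others in the source may bear on it.

Measured compounds:
compound 1, `CC(Cc1ccc(NCc2cccc(Oc3ccccc3)c2)cc1)C(=O)O`, which in a functional assay on CHO cells for agonist activity at Free fatty acid receptor 1 (Homo sapiens) (a higher number here means that more compound is needed for the effect, a lower number that less compound is needed), gives 100 nM
compound 2, `Cc1nc(-c2ccc(C(F)(F)F)cc2)sc1CNc1ccc(CC(C)C(=O)O)cc1`, which in this assay gives 355 nM
compound 3, `CC(CC(=O)O)c1ccc(NCc2cccc(Oc3ccccc3)c2)cc1`, which in this assay gives 126 nM

Compound 1 and compound 3 share one core and differ only by 1-(carboxymethyl)ethyl in place of 2-carboxypropyl on an aromatic carbon. This change gave a 1.3-fold higher number from compound 1 to compound 3 (0.10 log units; within the scatter), so the two acids are not separated. Compound 2 carries a different core; the difference between the two cores is not broken down here, and compound 2 stands with the highest of the three numbers, beyond the scatter from both compound 1 and compound 3. Compound 4, `Cc1nc(-c2ccc(C(F)(F)F)cc2)sc1CNc1ccc(C(C)CC(=O)O)cc1`, is not yet measured. It differs from compound 2 by 1-(carboxymethyl)ethyl in place of 2-carboxypropyl on an aromatic carbon, the same change that was made from compound 1 to compound 3, at the same place. Because that earlier step was a 1.3-fold higher number from compound 1 to compound 3 (0.10 log units; within the scatter), compound 4 is expected to change little from compound 2, with an estimated step of a 1.3-fold higher number from compound 2 to compound 4 (0.10 log units; within the scatter). Compound 4 is therefore estimated at 450 nM, with a range from 200 nM to 1000 nM.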

Compound 4, half-maximal effective concentration: 58.9 nM
For compound 4 the middle estimate is 7.6-fold (0.88 log units) above the measured one; the measured number lies below the stated range.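

In this assay, replacing 2-carboxypropyl with 1-(carboxymethyl)ethyl gave a 6.0-fold lower number from compound 2 to compound 4 (0.78 log units; beyond the scatter) on the core of compound 2. The same change therefore did not carry the same result from one core to the other: the same change on two cores in this assay, a 1.3-fold higher number (0.10 log units; within the scatter) from compound 1 to compound 3 and a 6.0-fold lower number (0.78 log units; beyond the scatter) from compound 2 to compound 4, 7.6-fold (0.88 log units) apart, beyond the scatter of two such steps. This shows that, for these two pairs, the result of the change differs with the core, but it does not show which part of the cores accounts for the difference, and two pairs set no rule for the series.

The compounds shown leave open how the change would behave on further cores. They also leave open how a longer chain ending in the carboxylic acid, or a tetrazole replacing that acid, would behave on either core.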